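A few compounds are considered here, and "the series" means these few. Any claim that something is new, unique, unknown or untested is made for them only; others in the source may bear on it.

Measured so far:
Compound 1, `CC(C)COc1ccc2c(Cl)ccnc2c1`: 2490 nM
Compound 2, `CN(C)CCNc1ccnc2cc(OCc3ccc(F)cc3)ccc12`: 370 nM
Compound 3, `Fc1ccc(COc2ccc3c(Cl)ccnc3c2)cc1`: 2070 nM

In a functional assay on HCT-116 cells (Homo sapiens) for cytotoxicity, read by MTT assay, with a stated time of 48 h (a lower number here means a stronger inhibitor, a higher number a weaker inhibitor), compound 1 gives the highest of the three numbers. Compound 3 lies within the scatter of it, so no order between those two can be stated; compound 2 lies beyond the scatter below it. Among the compounds with values here, the one measured step, a 5.6-fold higher number from compound 2 to compound 3 (0.75 log units; beyond the scatter), concerns a change on an aromatic carbon of the shared core and does not touch the chain on the ring oxygen.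

Compound 4, `C=CCOc1ccc2c(Cl)ccnc2c1`, differs from compound 1 by vinyl in place of isopropyl on a saturated chain carbon bound to an oxygen on an aromatic ring

Within the data shown here, no measured step alters this chain. Compound 1 and compound 3 carry different groups on the ring oxygen, and their two values fall within the scatter of each other; that is the only indication here, and it is not a counted step. Beyond that, nothing in the series speaks for a shift in either direction from trimming the chain on the ring oxygen. The step from compound 1 to compound 4 is therefore expected to stay within the scatter, a 1.0-fold higher number from compound 1 to compound 4 (0.00 log units; within the scatter). Compound 4 is estimated in this assay at 2500 nM, with a range from 1200 nM to 5200 nM.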

Compound 4, half-maximal inhibitory concentration: 2570 nM
For compound 4 the middle estimate is 1.0-fold (0.01 log units) below the measured one; low and high end bracket the measured number.
By their numbers in this assay, from the lowest: compound 2; then compounds 3, 1 and 4 (each within the scatter of the next).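

In this assay, within the data shown here, the isobutoxy to allyloxy change gives the first measured step on the chain at the ring oxygen: a 1.0-fold higher number from compound 1 to compound 4 (0.01 log units; within the scatter). With the chloro group kept on the core, this position therefore shows no readable response to vinyl in place of isopropyl on a saturated chain carbon bound to an oxygen on an aromatic ring, even though this change brings in a double bond outside aromatic rings and removes the branched end of the chain. No measurement on hand accounts for the two chains reading alike.

Still open, as far as these compounds go, is whether this position responds to groups of another kind, such as a primary amine, a carboxylic acid or a longer chain, since isobutyl and allyl are both small chains of carbon only. Also open, from the compounds shown here alone, is whether isobutoxy and allyloxy would still read alike on a core carrying (2-(dimethylamino)ethyl)amino in place of chloro, the group found in compound 2 at 370 nM, which has a different chain on the ring oxygen.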